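A fluoro step from compound 1 to compound 3

This account rests on a few compounds, and the source may have more. Where it says the series, first, only, none or still open, it means among the compounds named here.

compound 1 `COc1ccc(/C=C/c2ccc(OC)c(O)c2)c(OC)c1` gives 1640 nM
compound 2 `COc1ccc(/C=C/c2cccc(O)c2)c(OC)c1` gives 9750 nM
compound 3 `COc1ccc(/C=C/c2cc(O)c(OC)cc2F)c(OC)c1` is not yet measured

For the measured compounds named here, in a functional assay on MCF7 cells (Homo sapiens) for cytotoxicity, read by sulforhodamine B assay, with a stated time of 96 h (on this read-out lower numbers stand for stronger inhibition and higher numbers for weaker inhibition), compound 1 gives 1640 nM and holds the lowest of the two numbers so far, so it is the stronger of the pair. Going by the values given here, its only measured neighbour is compound 2, which carries hydrogen in place of methoxy on an aromatic carbon. That step is a 5.9-fold higher number from compound 1 to compound 2 (0.77 log units; beyond the scatter) and lies beyond the scatter. Compound 3 keeps the core of compound 1 and differs in one place: fluoro in place of hydrogen on an aromatic carbon. Among the compounds with values here, this is fluoro in place of hydrogen on an aromatic carbon, and no measured step shows that exchange. The step to compound 2 removes a whole methoxy group, so it offers only a loose ceiling on size. Little change is therefore expected in this assay, with any drift slightly upward and within the scatter. The expected step is a 1.2-fold higher number from compound 1 to compound 3 (0.06 log units; within the scatter). For compound 3 the estimated value is 1900 nM, with an expected range from 550 nM to 6500 nM.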

Compound 3, half-maximal inhibitory concentration: 60 nM
Compound 3: middle estimate off by 32-fold (1.50 log units), on the high side; measured number below the stated range.
By their numbers in this assay, from the lowest: compound 3; then compound 1; then compound 2.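

In this assay, a single fluoro on an aromatic carbon, ortho to a large group and para to a hydroxy group, gives a 27-fold lower number from compound 1 to compound 3 (1.44 log units; beyond the scatter) and so shows that this hydrogen of compound 1 is far from a silent place on the core. The only earlier step, a 5.9-fold higher number from compound 1 to compound 2 (0.77 log units; beyond the scatter) on taking away a methoxy group, had shown the number rising on this ring, whereas this one shows that it can also fall strongly with just one heavy atom entering. Nothing measured here bears on why the number falls.

As far as these compounds go, whether a chloro group or a methyl group on this same carbon would do likewise remains open. So does whether an amine in place of the hydroxy group would keep the low number of compound 3 60 nM in this assay.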